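The source may report more compounds than this note shows. Statements on the series, on what has been measured and on what is new or still open speak of the compounds shown alone.

Of the compounds shown here, three that share one core have been tested in a functional assay on HeLa cells (Homo sapiens) for cytotoxicity, read by MTT assay, with a stated time of 24 h; a lower number here means a stronger inhibitor, a higher number a weaker inhibitor. Compound 1 `C=CC1=C(C(=O)O)C(c2ccc(F)cc2)OC1` gives 67400 nM in this assay. Compound 2 `C=CC1=C(C(=O)NCC(C)C)C(c2ccc(Cl)c(Cl)c2)OC1` gives 60100 nM in this assay. Compound 3 `C=CC1=C(C(=O)Nc2ccccc2)C(c2ccc(Cl)c(Cl)c2)OC1` returns only a limit of this assay, > 100000 nM. Among the two numbers given, compound 1 has the highest, and the number for compound 2 lies within the usual scatter of it, so the two cannot be ranked. Among the compounds with values here, the one change with a measured step, phenyl in place of isobutyl on an amide-type nitrogen, gave an at least 1.6-fold higher number from compound 2 to compound 3 (0.22 log units; that floor lies within the scatter). That step has no known upper end because compound 3 sits at the limit of > 100000 nM in this assay, at which 1 of the 3 values shown sits.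

Compound 4 `C=CC1=C(C(=O)NCCCCC)C(c2ccc(F)cc2)OC1` has not been measured in this assay. Its change from compound 1 is pentylamino in place of hydroxy on a carbonyl carbon. Within the data shown here, no measured pair shows an amide taking the place of an acid, and the only measured step concerns the group on the amide nitrogen, so it bears on this change just indirectly; the numbers for compound 1 and compound 2, an acid and an amide, lie within the scatter of each other. Compound 4 is therefore expected at about 65000 nM, between 25000 nM and 160000 nM. The expected step of a 1.0-fold lower number from compound 1 to compound 4 (0.02 log units; within the scatter) is estimated to stay within the scatter.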

Compound 4, half-maximal inhibitory concentration: > 100000 nM
Compound 4: only a limit was reported; the forecaster's own chance of this, stated with the estimate: 30%; at least 1.5-fold (0.18 log units) between middle value and limit.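

In this assay, within the data shown here, the step from acid to amide on this carbonyl carbon now has a direct measurement, which the earlier compounds did not give, and pentylamino in place of hydroxy produced an at least 1.4-fold higher number from compound 1 to compound 4 (0.17 log units; that floor lies within the scatter) and so brought no stronger inhibition. The value of compound 4, > 100000 nM, is a limit of the assay and not a number, so the step has a floor but no known upper end, and that floor alone cannot separate a real loss from no change at all. From the compounds shown here alone, the true size of the step stays unknown because compound 4 sits at the end of what the assay reports, as compound 3 does: the limit of > 100000 nM in this assay, at which 2 of the 4 values shown sit.

The compounds shown leave open whether a methyl ester, or a shorter chain such as ethylamino, in place of hydroxy on this carbonyl carbon would give a readable number rather than another limit. They also leave open how a pentylamino amide would behave with the two chloro groups of compound 2 and compound 3 in place of the fluoro group, since no pair shown changes that group alone.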